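The source may report more compounds than this note shows. Statements on the series, on what has been measured and on what is new or still open speak of the compounds shown alone.

Measured in a functional assay on HepG2 cells (Homo sapiens) for cytotoxicity, read by XTT assay, with a stated time of 6 days; a lower number here means a stronger inhibitor, a higher number a weaker inhibitor:
compound 1 `CNc1ncnc2[nH]cc(Sc3cccs3)c12`: > 25000 nM
compound 2 `c1csc(Sc2c[nH]c3ncnc(-c4cccs4)c23)c1`: > 25000 nM
compound 3 `c1coc(-c2ncnc3[nH]cc(Sc4cccs4)c23)c1`: > 25000 nM

Each of these entries is a limit of the assay and not a number. Compound 3 therefore has no exact place in the series, and it shares (the limit of > 25000 nM in this assay, at which 3 of the 3 values shown sit). The next compound, compound 4 `COc1ncnc2[nH]cc(Sc3cccs3)c12`, carries methoxy in place of furan-2-yl on an aromatic carbon. The measured steps that bear on this change are a step that the two limits leave unreadable from compound 1 to compound 3 and a step that the two limits leave unreadable from compound 2 to compound 3, and neither gives a size. The step that the two limits leave unreadable from compound 1 to compound 2 gives none either. The expectation therefore rests only on all three compounds, with methylamino, thiophen-2-yl or furan-2-yl at this place, sharing that limit. No change beyond the scatter is expected in this assay, and no direction can be given. The expected step is a step that the limit leaves unreadable from compound 3 to compound 4. The estimate for compound 4 is 30000 nM, with an expected range from 12000 nM to 50000 nM, and a report of only a limit is the likeliest outcome.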

Compound 4, half-maximal inhibitory concentration: > 25000 nM
Compound 4 was reported as a limit; the forecaster's own chance of this, stated with the estimate: 85%; the middle value does not contradict the limit.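

In this assay compound 4 gives > 25000 nM as a limit of the assay and not a number. No new step can be read between compound 4 and compound 1, compound 2 or compound 3: the limit of > 25000 nM in this assay, at which 4 of the 4 values shown sit. In this assay the compounds shown leave open whether any group at this place changes the value.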